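Methyl added to compound 3 in the sulfonamide series

The source may hold more compounds than are shown below. What is called first, only, known or untested is meant among the compounds shown, and "the series" means these compounds.

Compound 3 `CS(=O)(=O)Nc1cccc2c1CCC2c1ncc[nH]1` is the starting point of this step. In a functional assay on CHO cells for agonist activity at Alpha-1B adrenergic receptor (Homo sapiens), read by FLIPR and calcium flux (on this read-out higher numbers stand for an effect only at larger amounts of compound and lower numbers for an effect already at smaller amounts), compound 3 gives > 10000 nM, which is a limit of the assay and not a number. Compound 2 `COc1cccc2c1CCC2c1ncc[nH]1` gives in this assay > 10000 nM, again a limit. Compound 1 `COc1c(C)ccc2c1CCC2c1ncc[nH]1` gives in this assay > 10000 nM, once more a limit. Taken together, (the limit of > 10000 nM in this assay, at which 3 of the 3 values shown sit), so no compound in the set has yet produced a readable number.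

The change to compound 4 `Cc1ccc2c(c1NS(C)(=O)=O)CCC2c1ncc[nH]1` is methyl in place of hydrogen on an aromatic carbon. Going by the values given here, two measured steps touch on it: a step that the two limits leave unreadable from compound 1 to compound 2 is the same kind of change run backwards, and a step that the two limits leave unreadable from compound 2 to compound 3 exchanges the group that the new methyl sits ortho to. Both steps are unreadable, so neither gives a size or a direction to carry over. On this footing compound 4 is expected to stay where compound 3 stands, with a step that the limit leaves unreadable from compound 3 to compound 4 no more than a guess at no movement beyond the scatter. Compound 4 is therefore estimated at 20000 nM, within 4000 nM to 100000 nM, and most probably the assay will again report only its limit.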

Compound 4, half-maximal effective concentration: > 10000 nM
Compound 4: no number, only a limit; the forecaster's own chance of this, stated with the estimate: 80%; the middle value is on the limit's open side.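

No new step can be read from compound 4, since its pairs with compound 3 and compound 1 both end in limits: the limit of > 10000 nM in this assay, at which 4 of the 4 values shown sit.

The compounds shown leave open whether any change on the shared core gives a readable half-maximal effective concentration, and hence the size and direction of either step.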